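The source may hold more compounds than are shown below. What is called first, only, known or untested is meant among the compounds shown, and "the series" means these compounds.

Going by the values given here, in a functional assay on MDA-MB-231 cells (Homo sapiens) for inhibition, read by MTT assay, with a stated time of 5 days (a higher number here means a weaker inhibitor, a lower number a stronger inhibitor), compound 2 (`Cc1cc(Nc2nc(NCc3ccc(Cl)cc3)nc3c2cnn3C2CCOCC2)n[nH]1`) gives 9420 nM, the highest of the three numbers so far, which makes it the weakest inhibitor of the set. Compound 3 (`Cc1cc(Nc2nc(NCc3ccc(Cl)cc3)nc3c2cnn3CC(C)(C)O)n[nH]1`) gives 3980 nM, and compound 1 (`Cc1cc(Nc2nc(NCc3ccc(F)cc3F)nc3[nH]ncc23)n[nH]1`) gives 2670 nM.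

Compound 4 (`Cc1cc(Nc2nc(NCc3ccc(F)cc3F)nc3c2cnn3C2CCOCC2)n[nH]1`) differs from compound 2 in one place: 2,4-difluorophenyl in place of 4-chlorophenyl on a saturated chain carbon bound to a nitrogen on an aromatic ring. Put simply, 2,4-difluorophenyl stands in place of 4-chlorophenyl on a saturated chain carbon bound to a nitrogen on an aromatic ring.

Among the compounds with values here, the only measured single-place step is modest, a 2.4-fold lower number from compound 2 to compound 3 (0.37 log units; beyond the scatter), and it concerns a different place, an aromatic nitrogen. It therefore shows only how large a step can be in this small set, not what this swap does. Compound 1 also carries the 2,4-difluorophenyl group and gives 2670 nM, but it differs from compound 2 elsewhere too, so it is only a weak hint towards a lower number.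

The expected change is small, an estimated 1.6-fold lower number from compound 2 to compound 4 (0.20 log units; within the scatter), which would stay within the scatter. For compound 4 the estimated value is 6000 nM, with an expected range from 2800 nM to 13000 nM.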

Compound 4, half-maximal inhibitory concentration: 2880 nM
Beside the measured number, compound 4's estimate is 2.1-fold (0.32 log units) above it; the range from low to high includes it.
By their numbers in this assay, from the lowest: compounds 1, 4 and 3 (each within the scatter of the next); then compound 2.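

In this assay, the swap can now be read on its own: with oxan-4-yl held fixed on the aromatic nitrogen, 2,4-difluorophenyl in place of 4-chlorophenyl gives a 3.3-fold lower number from compound 2 to compound 4 (0.51 log units; beyond the scatter) and so goes beyond the scatter. With 2,4-difluorophenyl in place, adding oxan-4-yl where compound 1 has hydrogen gives a 1.1-fold higher number from compound 1 to compound 4 (0.03 log units; within the scatter) and stays within the scatter, so this assay does not separate those two groups on that nitrogen. Nothing here explains why the swap changes the number.

The compounds shown leave open whether the same swap would lower the number with 2-hydroxy-2-methylpropyl on the aromatic nitrogen. On these data alone, they also leave open how a plain phenyl or 4-fluorophenyl would compare at this place, so the separate roles of the chlorine and of each fluorine remain unknown.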